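Swapping Bromo for Chloro on an Oxazolopyridine Pair

The source may report more compounds than this note shows. Statements on the series, on what has been measured and on what is new or still open speak of the compounds shown alone.

Two measured compounds set the scene. Compound 1 `COc1ccccc1-c1nc2ncccc2o1` and compound 2 `Brc1ccccc1-c1nc2cccnc2o1` were each tested in a functional assay on the whole organism for inhibition, with Rattus norvegicus as the target, at a dose of 30 mg/kg; a lower number here means less inhibition, a higher number more inhibition at the dose given (going by the name of the read-out). In this assay compound 1 gives 9%, while compound 2 gives 31%. Compound 2 thus stands highest of the two numbers, and its nearest neighbour, compound 1, lies well below it, a gap that is beyond the usual scatter of repeated measurements.

The next compound, compound 3 `Clc1ccccc1-c1nc2cccnc2o1`, has not yet been measured. It differs from compound 2 in a single place: chloro in place of bromo on an aromatic carbon. The swapped group sits on an aromatic carbon of a six-membered aromatic ring of carbon only, ortho to a group of 9 heavy atoms.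

Going by the values given here, no pair of measured compounds shows the effect of this exact change, so no measured step exists to lean on. The expected step is a number 6 percentage points lower from compound 2 to compound 3 (within the scatter), a small shift at most that stays within the scatter. Compound 3 is therefore estimated to give 25%, with a range from 8% to 42%.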

Compound 3, a percentage reported as inhibition, in the whole organism at one dose (the size of the read-out at that dose, not a potency): 50%
Compound 3: the middle estimate sits 25 percentage points below what was measured; measured number above the stated range.
By their numbers in this assay, from the lowest: compound 1; then compound 2; then compound 3.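

In this assay, putting chloro in place of bromo on this aromatic carbon, ortho to a group of 9 heavy atoms, gives a number 19 percentage points higher from compound 2 to compound 3 (beyond the scatter). Going by these compounds alone, compound 2 and compound 3 differ in this one place only, so this pair gives the first direct reading of what this position does: exchanging one halogen for another is enough to change the read-out, even though the counts of rings, hydrogen-bond donors, hydrogen-bond acceptors and net charge stay the same. No measurement shown here accounts for the difference between these two compounds.

The compounds shown compare only bromo and chloro at this carbon, so it remains open how a fluoro, a methyl, an amine or a carboxylic acid would behave there. This single pair also cannot show whether the same exchange would have a similar effect on a different core, or whether the step would hold at doses other than the one tested.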